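Swapping the Aniline Ring in a Weakly Cytotoxic Series

This account rests on a few compounds, and the source may have more. Where it says the series, first, only, none or still open, it means among the compounds named here.

Compound 1, `Fc1cccc(-c2nc(Nc3ccccc3)c3ccccc3n2)c1`: in a functional assay on COLO 205 cells (Homo sapiens) for cytotoxicity, read by MTT assay, with a stated time of 48 h (a higher number here means a weaker inhibitor, a lower number a stronger inhibitor), compound 1 gives > 50000 nM, which is a limit of the assay.
Compound 2, `Fc1cccc(-c2nc(Nc3ccccc3)c3cc(F)ccc3n2)c1`: in this assay compound 2 gives 49700 nM.
Compound 3, `Fc1cccc(-c2nc(Nc3ccccc3F)c3cc(F)ccc3n2)c1`: in this assay compound 3 gives > 50000 nM, again a limit.

Compound 3 therefore stands at the edge of what this assay reports, as described by the limit of > 50000 nM in this assay, at which 2 of the 3 values shown sit. Compound 4, `Fc1cccc(-c2nc(Nc3cccc(Br)c3)c3cc(F)ccc3n2)c1`, differs from compound 3 by 3-bromophenyl in place of 2-fluorophenyl on a nitrogen on an aromatic ring. The two measured steps, a number no higher from compound 1 to compound 2 (the limit leaves the size open) and a number no lower from compound 2 to compound 3 (the limit leaves the size open), each concern fluoro in place of hydrogen on an aromatic carbon; neither shares the present change, and neither has a readable size, so they offer no directional guide. Compound 4 is accordingly expected to remain weak, with an expected step of an at least 1.1-fold lower number from compound 3 to compound 4 (0.04 log units; that floor lies within the scatter). Compound 4 is estimated at 45000 nM, expected to lie between 15000 nM and 50000 nM.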

Compound 4, half-maximal inhibitory concentration: > 50000 nM
Compound 4: a limit, no number; the forecaster's own chance of this, stated with the estimate: 60%; middle value at least 1.1-fold (0.04 log units) away from the limit.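

Adding a bromo group to the phenyl ring gives a number no lower from compound 2 to compound 4 (the limit leaves the size open). Compound 3 and compound 4 are both limits, so the step between them cannot be read, and 3-bromophenyl on this nitrogen brings no more readable activity than 2-fluorophenyl did. The series now rests almost entirely at one edge of the reported range: the limit of > 50000 nM in this assay, at which 3 of the 4 values shown sit.

Going by these compounds, whether a substituent of another kind on this phenyl ring, such as an amine or a carboxylic acid, would give a readable value in this assay stays open. So does the order of compound 3 and compound 4.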